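Trifluoromethyl for fluoro: the step from compound 3 to compound 4

The source may hold more compounds than are shown below. What is called first, only, known or untested is meant among the compounds shown, and "the series" means these compounds.

Compound 1 `CC(C(=O)N1CCN(c2ccc(F)cc2)CC1)N1C(=O)CCC1=O`, compound 2 `CC(C(=O)N1CCN(c2ccccc2F)CC1)N1C(=O)CCC1=O` and compound 3 `CC(C(=O)N1CCN(c2cccc(F)c2)CC1)N1C(=O)CCC1=O` share one core and differ only in the fluorophenyl on the ring amine nitrogen. In a functional assay on the whole organism (strain Swiss) with Mus musculus as the target, in the maximal electroshock model, with a stated time of 0.5 h, at a dose of 100 mg/kg by the intraperitoneal route (on this read-out lower numbers stand for a weaker effect and higher numbers for a stronger effect at the one dose given), compound 1 gives 0%, compound 2 gives 0% and compound 3 gives 0%. Moving the fluoro about the ring changed nothing: no change at the digits printed from compound 1 to compound 2 (within the scatter), no change at the digits printed from compound 1 to compound 3 (within the scatter) and no change at the digits printed from compound 2 to compound 3 (within the scatter). Compound 3 therefore stands level with compounds 1 and 2 at the digits shown, at the floor of the read-out.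

Compound 4 `CC(C(=O)N1CCN(c2cccc(C(F)(F)F)c2)CC1)N1C(=O)CCC1=O` is not yet measured. It differs from compound 3 in one place: trifluoromethyl in place of fluoro on an aromatic carbon. Among the measured compounds shown here, no measured step involves a trifluoromethyl group; the three steps that exist only move a fluoro and all lie within the scatter, so they give no direction for this change. With every measured compound at the floor, a rise beyond the scatter cannot be excluded but has no support. For compound 4 the expected value in this assay is 0%, with a range from 0% to 25%. The expected step is no change at the digits printed from compound 3 to compound 4 (within the scatter), no change beyond the scatter.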

Compound 4, a percentage reported as activity, at one dose (the size of the read-out at that dose, not a potency): 75%
The estimate for compound 4 lay 75 percentage points below the measured number; measured number above the stated range.
By their numbers in this assay, from the lowest: compounds 1, 2 and 3 (each within the scatter of the next); then compound 4.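

At this position, on an aromatic carbon meta to a large group, the choice of substituent matters in this assay: trifluoromethyl in place of fluoro gives a number 75 percentage points higher from compound 3 to compound 4 (beyond the scatter). Compounds 1, 2 and 3 showed only that moving a fluoro around the ring leaves the read-out at the floor, whereas compound 4 shows that the shared core can lift off that floor through a single change on this ring. Nothing at hand bears on what lies behind this step.

Open, from the compounds shown here alone, is whether trifluoromethyl elsewhere on the ring would give a similar number. Also open, going by these compounds, is whether the step needs trifluoromethyl itself, or whether a methyl group, a chlorine atom or a nitrile on the same carbon would give a comparable read-out.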